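The source may report more compounds than this note shows. Statements on the series, on what has been measured and on what is new or still open speak of the compounds shown alone.

Three closely related compounds have been tested for their effect on cell growth. Compound 1 `ClCc1ccc(Cn2cnc3c(Cl)ncnc32)cc1` gives 3890 nM in a functional assay on MDA-MB-231 cells (Homo sapiens) for cytotoxicity, read by sulforhodamine B assay, with a stated time of 48 h; a higher number here means a weaker inhibitor of growth, a lower number a stronger inhibitor of growth. Compound 2 `Nc1nc(Cl)c2ncn(Cc3ccc(CCl)cc3)c2n1` carries one change relative to compound 1, (amino in place of hydrogen on an aromatic carbon), and in this assay compound 2 gives 34700 nM; this step is an 8.9-fold higher number from compound 1 to compound 2 (0.95 log units; beyond the scatter). Compound 3 `ClCc1ccccc1Cn1cnc2c(Cl)ncnc21` has the same atoms as compound 1 joined differently; the difference between the two cores is not broken down here. In this assay compound 3 gives 7410 nM. Compound 4 `Nc1nc(Cl)c2ncn(Cc3ccccc3CCl)c2n1` has not yet been measured; it differs from compound 3 by amino in place of hydrogen on an aromatic carbon, the same change at the same place as the one already seen. The expectation for compound 4 rests on that earlier step, an 8.9-fold higher number from compound 1 to compound 2 (0.95 log units; beyond the scatter). A step of similar size is expected, an 8.1-fold higher number from compound 3 to compound 4 (0.91 log units; beyond the scatter). For compound 4 the value expected in this assay is about 60000 nM, between 20000 nM and 180000 nM.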

Compound 4, concentration for total growth inhibition: 9550 nM
Beside the measured number, compound 4's estimate is 6.3-fold (0.80 log units) above it, outside the stated range (below it).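

The same change does not carry the same step from one core to the other: the same change on two cores in this assay, an 8.9-fold higher number (0.95 log units; beyond the scatter) from compound 1 to compound 2 and a 1.3-fold higher number (0.11 log units; within the scatter) from compound 3 to compound 4, 6.9-fold (0.84 log units) apart, beyond the scatter of two such steps. In this assay, amino in place of hydrogen on the core of compound 3 gives only a step within the scatter (a 1.3-fold higher number from compound 3 to compound 4 (0.11 log units; within the scatter)), so a step read on one core cannot simply be carried over to the other in this series. These two pairs do not show why the steps differ, nor how the change would behave on any further core.

From the compounds shown here alone, it remains open whether a methylamino group or a hydroxyl group in the same place, between two ring nitrogen atoms, would follow the larger step, the smaller one or neither.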